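Urea series: working notes on the step to compound 4

A few compounds are considered here, and "the series" means these few. Any claim that something is new, unique, unknown or untested is made for them only; others in the source may bear on it.

Measured so far in a functional assay on OS-RC-2 cells (Homo sapiens) for cytotoxicity, read by MTT assay, with a stated time of 72 h; a higher number here means a weaker inhibitor, a lower number a stronger inhibitor:
- compound 1 `O=C(Nc1ccc(-n2ncc3c(Br)cccc32)cc1)Nc1ccc(Cl)c(C(F)(F)F)c1`: 9900 nM
- compound 2 `O=C(Nc1ccc(-n2ncc3c(F)cccc32)cc1)Nc1ccc(Cl)c(C(F)(F)F)c1`: 32000 nM
- compound 3 `Cc1cccc2c1cnn2-c1ccc(NC(=O)Nc2ccc(Cl)c(C(F)(F)F)c2)cc1`: 32000 nM

Compound 3 sits level with compound 2 at the digits printed; together they give the highest numbers of the three. Compound 1 is the furthest from compound 3, the change being a 3.2-fold higher number from compound 1 to compound 3 (0.51 log units; beyond the scatter). The parallel change a 3.2-fold higher number from compound 1 to compound 2 (0.51 log units; beyond the scatter) has the same size, and between compound 2 and compound 3 there is no change at the digits printed from compound 2 to compound 3 (within the scatter).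

Compound 4 `O=C(Nc1ccc(-n2ncc3ccccc32)cc1)Nc1ccc(Cl)c(C(F)(F)F)c1` is not yet measured. It differs from compound 3 by hydrogen in place of methyl on an aromatic carbon, that is, 4-methyl-1H-indazol-1-yl becomes 1H-indazol-1-yl.

Among the compounds with values here, no measured step removes a group from this position altogether; the nearest comparisons are the exchanges among bromo, fluoro and methyl at that carbon. Those show that bromo gives the lowest number and that fluoro and methyl give the same higher number. Hydrogen at this position has no direct precedent, so the expectation for compound 4 rests on the flat step from compound 2 to compound 3. Compound 4 is expected to give about 40000 nM, within 15000 nM to 100000 nM, the estimated step being a 1.3-fold higher number from compound 3 to compound 4 (0.10 log units; within the scatter).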

Compound 4, half-maximal inhibitory concentration: 32000 nM
Compound 4: the middle estimate sits 1.3-fold (0.10 log units) above what was measured; measured number inside the range.
By their numbers in this assay, from the lowest: compound 1; then compounds 2, 3 and 4 (each within the scatter of the next).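

In this assay the bare hydrogen compound now gives a baseline for this aromatic carbon, and taking the methyl away changes nothing measurable (no change at the digits printed from compound 3 to compound 4 (within the scatter)), nor does taking the fluoro away (no change at the digits printed from compound 2 to compound 4 (within the scatter)). Hydrogen, fluoro and methyl therefore cannot be told apart here, and bromo is the only group of the four that stands apart from the unsubstituted compound (a 3.2-fold higher number from compound 1 to compound 4 (0.51 log units; beyond the scatter)), a modest step that runs towards the lower number with bromo present. No measurement at hand bears on what sets the bromo group apart from the other three.

The compounds shown leave open whether chloro or iodo on this carbon would sit with bromo or with the hydrogen compound, and whether an amine, a methoxy group or a carboxylic acid would move the number in either direction. They also leave open whether the bromo step would carry over to a urea partner other than the 4-chloro-3-trifluoromethylphenyl group shared by all four compounds.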